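The compounds below may be only part of what the source reports. "The series", "measured", "known", "first", "only" and "open" are said of these compounds alone.

Among the measured compounds shown here, compound 2 `C[C@@H](Cn1ccc(-c2ccc(C#N)c(Cl)c2)n1)Nc1ccccn1` gives 1110 nM in a functional assay on LNCaP cells (Homo sapiens) for antiproliferative activity, read by CCK-8 assay, with a stated time of 6 days (on this read-out higher numbers stand for weaker inhibition and lower numbers for stronger inhibition), the lowest of the two numbers so far. Its nearest neighbour is compound 1 `C[C@@H](Cn1ccc(-c2ccc(C#N)c(Cl)c2)n1)NS(=O)(=O)c1cccnc1`, which in this assay gives 6140 nM. For the measured compounds named here, the single step measured, a 5.5-fold lower number from compound 1 to compound 2 (0.74 log units; beyond the scatter), swaps a sulfonyl-linked ring for a ring bound directly to the amine nitrogen. Compound 3 `C[C@@H](Cn1ccc(-c2ccc(C#N)c(Cl)c2)n1)Nc1ncccn1` differs from compound 2 by pyrimidin-2-yl in place of pyridin-2-yl on an amine nitrogen. Going by the values given here, no measured step replaces one six-membered aromatic ring directly attached to this nitrogen with another, so the earlier step concerns the linker rather than the ring and bears on the present change only loosely. A step within the usual scatter is therefore expected in this assay, with no clear direction. The estimate for compound 3 is 1500 nM, between 500 nM and 4500 nM. This corresponds to an expected 1.4-fold higher number from compound 2 to compound 3 (0.13 log units; within the scatter).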

Compound 3, half-maximal inhibitory concentration: 1180 nM
The estimate for compound 3 lay 1.3-fold (0.10 log units) above the measured number; measured number inside the range.
By their numbers in this assay, from the lowest: compounds 2 and 3 (each within the scatter of the next); then compound 1.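

Among the compounds shown here, on the amine nitrogen, this assay does not separate pyrimidin-2-yl from pyridin-2-yl: the step is a 1.1-fold higher number from compound 2 to compound 3 (0.03 log units; within the scatter), so this exchange of one six-membered aromatic ring for another is the first change at this position to stay within the scatter. The difference from the sulfonyl-linked compound also recurs with the second directly bound ring, at a 5.2-fold lower number from compound 1 to compound 3 (0.72 log units; beyond the scatter), so it is no longer seen for pyridin-2-yl alone. Nothing available explains either step.

On these data alone, it remains open whether the same flat response holds for a plain phenyl ring or a pyrazin-2-yl ring on this nitrogen. Also open, as far as these compounds go, is how a non-aromatic group, such as an acetyl group or a cyclohexyl ring, would compare with these directly bound rings.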